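Trifluoromethylphenyl for naphthalen-2-yl on the triazole nitrogen

The compounds below may be only part of what the source reports. "The series", "measured", "known", "first", "only" and "open" are said of these compounds alone.

The series shares one core, measured in a functional assay on HeLa cells (Homo sapiens) for antiproliferative activity, with a stated time of 5 days; a higher number here means a weaker inhibitor, a lower number a stronger inhibitor. Compound 1 `O=C1C=CC2(C=C1)OCC(=O)N2c1nc(-c2ccc3ccccc3c2)nn1-c1ccc2ccccc2c1` gives 210 nM and stands second highest of the three numbers. Within the data shown here, compound 2 `CC1OC2(C=CC(=O)C=C2)N(c2nc(-c3ccc4ccccc4c3)nn2-c2ccc3ccccc3c2)C1=O` gives 300 nM; the only single-place step recorded, a 1.4-fold higher number from compound 1 to compound 2 (0.15 log units; within the scatter), concerns a methyl in place of hydrogen on a saturated ring carbon and lies within the scatter. Among the measured compounds shown here, compound 3 `O=C1C=CC2(C=C1)OCC(=O)N2c1nc(-c2cccc(Cl)c2)nn1-c1ccccc1` gives 45.3 nM, a lower number than compound 1 beyond the scatter, but compound 3 differs from compound 1 at more than one place, so no single step is drawn from it.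

Compound 4 `O=C1C=CC2(C=C1)OCC(=O)N2c1nc(-c2ccc3ccccc3c2)nn1-c1ccc(C(F)(F)F)cc1` is not yet measured. It differs from compound 1 by 4-(trifluoromethyl)phenyl in place of naphthalen-2-yl on an aromatic nitrogen. For the measured compounds named here, no recorded step touches this aromatic nitrogen, and the one step available, a 1.4-fold higher number from compound 1 to compound 2 (0.15 log units; within the scatter), is at an unrelated position and within the scatter. The values of compound 1 and compound 3 show only that a smaller aryl substitution pattern on the core is compatible with a lower number. Going by the values given here, with no direct precedent, the expected step is small: compound 4 is expected to give 150 nM, range 50 nM to 450 nM, the estimated step of a 1.4-fold lower number from compound 1 to compound 4 (0.15 log units; within the scatter) being not clearly beyond the scatter.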

Compound 4, half-maximal inhibitory concentration: 390 nM
The estimate for compound 4 lay 2.6-fold (0.41 log units) below the measured number; the measured number falls inside the stated range.
By their numbers in this assay, from the lowest: compound 3; then compounds 1, 2 and 4 (each within the scatter of the next).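

Among these compounds, this is the first step recorded at the aromatic nitrogen of the five-membered aromatic ring. In this assay, 4-(trifluoromethyl)phenyl in place of naphthalen-2-yl gives a 1.9-fold higher number from compound 1 to compound 4 (0.27 log units; within the scatter), so replacing two six-membered aromatic rings of carbon with one, at an equal count of heavy atoms, produces no change that can be told from repeat-measurement noise, and this position accepts the exchange without a clear penalty or gain. No measured property of either group bears on this result.

From the compounds shown here alone, with one step at this position, it remains open whether the lack of a clear change extends to aryl groups other than these two, or whether a carboxylic acid or a primary amine in place of the trifluoromethyl would move the number beyond the scatter. Among the compounds shown here, the group on the other side of the ring, the naphthalen-2-yl on carbon, also has no single-place step of its own, so how its exchange would compare with the step at this nitrogen cannot yet be read.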